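Phenyl for difluorophenyl swap, carried to the oxime analogue

The compounds below may be only part of what the source reports. "The series", "measured", "known", "first", "only" and "open" are said of these compounds alone.

Compound 1 `Cc1c(C=O)cc(-c2ccc(S(C)(=O)=O)cc2)n1-c1ccc(F)c(F)c1` is the reference of this small set. In a functional assay on the whole organism (strain Swiss albino) for inhibition, with Mus musculus as the target, in the writhing test, with a stated time of 30 min, at a dose of 10 mg/kg by the oral route (on this read-out lower numbers stand for a weaker effect and higher numbers for a stronger effect at the one dose given), compound 1 gives 53%. Compound 2 `Cc1c(C=O)cc(-c2ccc(S(C)(=O)=O)cc2)n1-c1ccccc1` differs from it by phenyl in place of 3,4-difluorophenyl on an aromatic nitrogen, and in this assay compound 2 gives 23%, so that a number 30 percentage points lower from compound 1 to compound 2 (beyond the scatter). Compound 3 `Cc1c(/C=N\O)cc(-c2ccc(S(C)(=O)=O)cc2)n1-c1ccc(F)c(F)c1` differs from compound 1 in the core by a group of 3 heavy atoms (1 carbon, 1 nitrogen, 1 oxygen; no ring) in place of a group of 2 heavy atoms (1 carbon, 1 oxygen; no ring), on an aromatic carbon; in this assay compound 3 gives 19%, with a number 34 percentage points lower from compound 1 to compound 3 (beyond the scatter). The numbers of compound 2 and compound 3 lie within the scatter of each other.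

Compound 4 `Cc1c(/C=N\O)cc(-c2ccc(S(C)(=O)=O)cc2)n1-c1ccccc1` is not yet measured. It differs from compound 3 by phenyl in place of 3,4-difluorophenyl on an aromatic nitrogen. Among the measured compounds shown here, this is the same kind of change as the one from compound 1 to compound 2, but the surroundings of the place differ: in that pair the aromatic nitrogen lies two ring bonds from the ring atom that bears a formyl group (2 heavy atoms), whereas in compound 3 and compound 4 it lies two ring bonds from the ring atom that bears a group of 3 heavy atoms. For the measured compounds named here, the only precedent is the single step seen once.

For compound 4 a downward step of a number 9 percentage points lower from compound 3 to compound 4 (within the scatter) in this assay is expected, smaller than the earlier one because a number 30 percentage points lower from compound 1 to compound 2 (beyond the scatter) started from a far higher number, while compound 3 already stands near the bottom of the read-out. The estimate for compound 4 in this assay is 10%, expected to fall between 0% and 28%.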

Compound 4, a percentage reported as inhibition, in the whole organism at one dose (the size of the read-out at that dose, not a potency): 27%
Compound 4: middle estimate off by 17 percentage points, on the low side; the range from low to high includes it.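

With a number 8 percentage points higher from compound 3 to compound 4 (within the scatter) in this assay, phenyl in place of 3,4-difluorophenyl on the aromatic nitrogen does not repeat on the core of compound 3 the fall seen on the core of compound 1: the same change on two cores in this assay, a number 30 percentage points lower (beyond the scatter) from compound 1 to compound 2 and a number 8 percentage points higher (within the scatter) from compound 3 to compound 4, 38 percentage points apart, beyond the scatter of two such steps

Likewise, with a number 4 percentage points higher from compound 2 to compound 4 (within the scatter), the group of 3 heavy atoms in place of the formyl group does not repeat its fall once phenyl stands on the aromatic nitrogen: the same change on two cores in this assay, a number 34 percentage points lower (beyond the scatter) from compound 1 to compound 3 and a number 4 percentage points higher (within the scatter) from compound 2 to compound 4, 38 percentage points apart, beyond the scatter of two such steps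

In this set, then, the size of each change depends on the core that carries it, so a step read on one core cannot simply be transferred to the other, but these few compounds, tested at a single dose, do not show why this is so or how any further core would behave.

Still open, going by these compounds, is how other groups on the aromatic nitrogen, such as 4-fluorophenyl or benzyl, would behave on the formyl and oxime cores. Also open, on these data alone, is whether a carboxylic acid or a nitrile on the same aromatic carbon would follow compound 1 or compound 3 when the 3,4-difluorophenyl is exchanged for phenyl.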